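Swapping a sulfo group for hydroxy on a sugar-lipid

This account rests on a few compounds, and the source may have more. Where it says the series, first, only, none or still open, it means among the compounds named here.

Compound 1 `CCCCCCCCCCCC(=O)OCC(COC(=O)CCCCCCCCCCC)O[C@@H]1O[C@H](CS(=O)(=O)O)[C@@H](O)[C@H](O)[C@H]1O` is a glycolipid: a sugar ring carrying a sulfomethyl group, joined to a glycerol backbone that bears two long ester chains. In an assay on isolated protein for inhibition of RAC-alpha serine/threonine-protein kinase (Homo sapiens), read by ELISA, tested at 100 uM (a lower number here means less inhibition, a higher number more inhibition at the concentration tested (going by the name of the read-out)), compound 1 gives 77%, the highest of the three numbers measured here, and both of the others lie beyond the scatter below it. Compound 2 `CCCCCC(=O)OCC(CO)O[C@@H]1O[C@H](CS(=O)(=O)O)[C@@H](O)[C@H](O)[C@H]1O` keeps the sulfo group but carries a single shorter ester chain and a free hydroxy on the glycerol; in this assay compound 2 gives 18%. Compound 3 `CCCCCCCCO[C@@H]1O[C@H](CN)[C@@H](O)[C@H](O)[C@H]1O` has an octyl ether in place of the glycerol diester and an aminomethyl group instead of sulfomethyl; in this assay compound 3 gives 6%.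

Compound 4 `CCCCCCCCCCCC(=O)OCC(COC(=O)CCCCCCCCCCC)O[C@@H]1O[C@H](CO)[C@@H](O)[C@H](O)[C@H]1O` keeps the two long ester chains of compound 1 and differs only in one group: hydroxy in place of sulfo on a saturated chain carbon bound to a saturated ring carbon. For the measured compounds named here, no measured pair here isolates this change. Because compound 1 gives 77% while the sulfo-free compound 3 gives 6%, a drop beyond the scatter is expected from compound 1 to compound 4, estimated at a number 42 percentage points lower from compound 1 to compound 4 (beyond the scatter). Compound 4 is accordingly expected to reach about 35%, within a range from 8% to 65%.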

Compound 4, a percentage reported as inhibition, at one concentration (the size of the read-out at that concentration, not a potency): 7%
The estimate for compound 4 lay 28 percentage points above the measured number, and the stated range ends above it.
By their numbers in this assay, from the lowest: compounds 3 and 4 (each within the scatter of the next); then compound 2; then compound 1.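

With the two long ester chains held fixed, the change from sulfomethyl to hydroxymethyl gives, in this assay, a number 70 percentage points lower from compound 1 to compound 4 (beyond the scatter), a large step from this one change. The earlier compounds shown here each differed in more than one place, so they could not separate the sulfo group from the chains; this pair shows that the two long ester chains on their own do not preserve the inhibition seen with compound 1 at the concentration tested. No measurement shown here explains how the sulfo group produces this difference.

Going by these compounds, it remains open whether the sulfo group is specifically required, or whether a carboxylic acid or a phosphonic acid in its place on the same chain carbon would restore the inhibition. On these data alone, it is also open how much inhibition depends on the length of the ester chains when the sulfo group stays in place, for example with a longer chain.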